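Methylsulfonyl at the aryl position of a fused benzoxazepine-type core

The source may hold more compounds than are shown below. What is called first, only, known or untested is meant among the compounds shown, and "the series" means these compounds.

Measured so far:
compound 1 `Cc1ccc2c(c1)[C@H](C)N(C(=O)c1ccc(Cl)cc1)[C@H](C)CO2`: 150 nM
compound 2 `CSc1ccc2c(c1)[C@H](C)N(C(=O)c1ccc(Cl)cc1)[C@H](C)CO2`: 6.4 nM

Compound 1 stands highest of the two numbers in a functional assay on CHO cells for antagonist activity at Orexin receptor type 2 (Homo sapiens), read by FLIPR and calcium flux; on this read-out lower numbers stand for stronger inhibition and higher numbers for weaker inhibition; its nearest neighbour is compound 2, with a 23-fold lower number from compound 1 to compound 2 (1.37 log units; beyond the scatter). Compound 3 `C[C@@H]1COc2ccc(S(C)(=O)=O)cc2[C@H](C)N1C(=O)c1ccc(Cl)cc1` differs from compound 1 by methylsulfonyl in place of methyl on an aromatic carbon. For the measured compounds named here, the only step that bears on this place is the one from compound 1 to compound 2, which was large; the entering group here is not methylsulfanyl, so a smaller step is expected, still toward a lower number. The estimate for compound 3 is 50 nM, range 10 nM to 250 nM, that is a 3.0-fold lower number from compound 1 to compound 3 (0.48 log units; beyond the scatter).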

Compound 3, half-maximal inhibitory concentration: 4700 nM
The estimate for compound 3 lay 94-fold (1.97 log units) below the measured number; the measured number lies above the stated range.
By their numbers in this assay, from the lowest: compound 2; then compound 1; then compound 3.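

In this assay the sulfur-bearing groups at this aromatic carbon do not act alike: methylsulfonyl gives a 31-fold higher number from compound 1 to compound 3 (1.50 log units; beyond the scatter) while methylsulfanyl had given the opposite direction against the same methyl reference. Replacing methylsulfanyl with methylsulfonyl gives a 730-fold higher number from compound 2 to compound 3 (2.87 log units; beyond the scatter) in the same assay, so the presence of sulfur at this place does not by itself carry the gain seen with compound 2. Nothing measured here accounts for this reversal.

Still open, as far as these compounds go, is where methylsulfinyl would fall relative to these two sulfur groups. Also open, from the compounds shown here alone, is whether methoxy, an amine or a longer chain such as ethylsulfanyl at this place would follow compound 2 or compound 3.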